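Half-life of a benzyl compound without its methyl

The compounds below may be only part of what the source reports. "The series", "measured", "known", "first", "only" and "open" are said of these compounds alone.

- compound 1 `Cc1ccc(CO[P@@]2(=O)OC[C@H]3O[C@@H](n4cnc5c(N)ncnc54)[C@H](O)[C@@H]3O2)cc1`: 9.5 h
- compound 2 `Nc1ncnc2c1ncn2[C@@H]1O[C@@H]2CO[P@@](=O)(OCc3ccc([N+](=O)[O-])cc3)O[C@H]2[C@H]1O`: 3 h

Both half-lives come from a physicochemical assay for metabolic stability, at 30 degrees C, at pH 6.5; on this read-out lower numbers stand for a shorter-lived compound and higher numbers for a longer-lived compound. Compound 1 stands higher of the two at 9.5 h, and compound 2 gives 3 h, a gap beyond the usual scatter. These two compounds do not differ in just one place, so their gap cannot be read as the effect of a single change.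

The next compound to be measured is compound 3 `Nc1ncnc2c1ncn2[C@@H]1O[C@@H]2CO[P@](=O)(OCc3ccccc3)O[C@H]2[C@H]1O`. It departs from compound 1 by one small edit, (hydrogen in place of methyl on an aromatic carbon), with hydrogen in place of methyl on an aromatic carbon, turning 4-methylbenzyl into benzyl. Within the data shown here, no measured pair shows this change on its own, so any expectation is tentative. The reference point is compound 1 at 9.5 h, and the edit is small. In this assay, the expected 1.4-fold lower number from compound 1 to compound 3 (0.13 log units; within the scatter) is modest, slightly downward if anything, and within the usual scatter. For compound 3 the estimated half-life is 7 h, with an expected range from 3.5 h to 13 h.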

Compound 3, half-life: 9.5 h
Compound 3: the middle estimate sits 1.4-fold (0.13 log units) below what was measured; measured number inside the range.
By their numbers in this assay, from the lowest: compound 2; then compounds 1 and 3 (each within the scatter of the next).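

In this assay there is no change at the digits printed from compound 1 to compound 3 (within the scatter), with hydrogen in place of methyl on an aromatic carbon, turning 4-methylbenzyl into benzyl. Among these compounds, this is the first reading of a single change, since the two earlier compounds differ in more than one place, and it shows that at this position on the six-membered aromatic ring, para to a large group, the methyl can be dropped without any visible shift in half-life. No measured information is available that would account for this flat step.

As far as these compounds go, what remains open is how far this tolerance extends: one step between methyl and hydrogen says nothing about how an amine, a carboxylic acid or a longer chain such as propyl would behave at the same position. From the compounds shown here alone, it is also open whether a group such as methoxy or chlorine on the benzyl ring would leave the half-life equally unmoved, or whether the same edit would read the same way on a different core.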